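Replacing the carboxy group of compound 1 with a morpholine amide

The source may report more compounds than this note shows. Statements on the series, on what has been measured and on what is new or still open speak of the compounds shown alone.

Measured compounds:
compound 1, `O=C(O)Cn1nc(CC(=O)Nc2ccc(OC(F)(F)F)c(Cl)c2)c2ccccc2c1=O`, 754 nM
compound 2, `C[C@@H](C(=O)O)c1nn(Cc2cn3cc(OCC4CC4)c(Cl)cc3n2)c2ccccc2c1=O`, 253 nM
compound 3, `COc1cc(OC)c(NC(=O)Cc2cn(C)c3ccccc23)cc1Cl`, 19200 nM

All three were tested in a functional assay on CHO cells for antagonist activity at sphingosine 1-phosphate receptor 2 (Homo sapiens), read by GTPgammaS binding; a lower number here means a stronger inhibitor, a higher number a weaker inhibitor. Among these three numbers compound 1 stands second highest: compound 2 sits at a lower number, beyond the usual scatter, while compound 3 sits far higher. Compound 1 therefore holds a middle place, clearly weaker than compound 2 yet much stronger than compound 3.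

The unmeasured compound 4, `O=C(Cc1nn(CC(=O)N2CCOCC2)c(=O)c2ccccc12)Nc1ccc(OC(F)(F)F)c(Cl)c1`, shares the core of compound 1 and its amide-linked aryl group. Within the data shown here, the single change is morpholin-4-yl in place of hydroxy on a carbonyl carbon. Among the measured compounds shown here, no measured pair in this set isolates that kind of change, so there is no direct precedent to lean on; the expectation rests only on the general observation that a neutral group has replaced the hydroxy on the carbonyl carbon. A moderate step toward a higher number from compound 1 to compound 4 is expected, a 2.4-fold higher number from compound 1 to compound 4 (0.38 log units; beyond the scatter), larger than the scatter but far short of the distance to compound 3. Compound 4 is accordingly estimated at 1800 nM, within a range of 450 nM to 7000 nM.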

Compound 4, half-maximal inhibitory concentration: 103 nM
Compound 4: the middle estimate sits 17-fold (1.24 log units) above what was measured; measured number below the stated range.
By their numbers in this assay, from the lowest: compound 4; then compound 2; then compound 1; then compound 3.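

In this assay, the carboxy group of compound 1 turns out not to be required for inhibition. Morpholin-4-yl in place of hydroxy on a carbonyl carbon gives a stronger inhibitor, not a weaker one (a 7.3-fold lower number from compound 1 to compound 4 (0.86 log units; beyond the scatter)). This is the first single-place comparison in the set, and it shows that this position accepts a six-membered non-aromatic ring and the loss of the hydroxy hydrogen-bond donor; nothing shown explains the size of the step.

Open, on these data alone, is whether the gain depends on the morpholine ring or would also appear with a piperidine amide, a dimethylamide or a methyl ester on the same carbonyl carbon. Also open, as far as these compounds go, is whether a morpholine amide in place of the carboxylic acid of compound 2 would move the number the same way.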